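Moving the Hydroxy Around the Phenyl Ring

A few compounds are considered here, and "the series" means these few. Any claim that something is new, unique, unknown or untested is made for them only; others in the source may bear on it.

Measured compounds:
compound 1, `COC(=O)c1ccccc1-c1cnc(C(=O)CCCCCCc2ccccc2)o1`: 60 nM
compound 2, `COC(=O)c1cccc(-c2cnc(C(=O)CCCCCCc3ccccc3)o2)c1`: 12 nM
compound 3, `O=C(CCCCCCc1ccccc1)c1ncc(-c2cccc(O)c2)o1`: 50 nM

In an assay (Rattus norvegicus) for inhibition of Fatty-acid amide hydrolase 1 (Homo sapiens) (a lower number here means a stronger inhibitor, a higher number a weaker inhibitor), compound 3 holds the second highest of the three numbers. Its nearest neighbour is compound 1, whose value lies within the scatter of that of compound 3, so no order between them can be read. Among the measured compounds shown here, compound 2 stands apart: the one step with numbers here, a 4.2-fold higher number from compound 2 to compound 3 (0.62 log units; beyond the scatter), replaces methoxycarbonyl by hydroxy and raises the number beyond the scatter.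

Compound 4, `O=C(CCCCCCc1ccccc1)c1ncc(-c2ccc(O)cc2)o1`, differs from compound 3 only in the position of the hydroxy: 4-hydroxyphenyl in place of 3-hydroxyphenyl on an aromatic carbon. For the measured compounds named here, no measured step moves a hydroxy from one ring position to another, so nothing bears on this change directly. The closest hint is that compound 1 gives 60 nM while compound 2 gives 12 nM for a methoxycarbonyl in two different positions, which shows that the position of a group can matter. With no direction to lean on, compound 4 is expected to land near compound 3, with a step of about a 1.1-fold lower number from compound 3 to compound 4 (0.05 log units; within the scatter) in this assay, most likely within or just beyond the scatter. The estimate for compound 4 is 45 nM, in a range from 15 nM to 130 nM.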

Compound 4, inhibition constant: 140 nM
The estimate for compound 4 lay 3.1-fold (0.49 log units) below the measured number; the measured number lies above the stated range.
By their numbers in this assay, from the lowest: compound 2; then compounds 3 and 1 (each within the scatter of the next); then compound 4.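

In this assay, moving the hydroxy alone gives a 2.8-fold higher number from compound 3 to compound 4 (0.45 log units; beyond the scatter), so 3-hydroxyphenyl and 4-hydroxyphenyl are not interchangeable on this aromatic carbon, next to the ring oxygen, even though the two groups have the same atoms. Among the compounds shown here, until this result, the only sign that position matters on this phenyl ring came from methoxycarbonyl, where compound 1 gives 60 nM and compound 2 gives 12 nM; the pair of compound 3 and compound 4 now shows a hydroxy's position mattering too, beyond the scatter. Nothing measured here accounts for this difference. On these data alone, it remains open how 2-hydroxyphenyl would compare on the same carbon. Also open, as far as these compounds go, is whether an amine or a carboxylic acid on the phenyl ring would show a similar dependence on position.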